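Aryl swap at the benzylic carbon: compound 3 to compound 4

The compounds below may be only part of what the source reports. "The series", "measured", "known", "first", "only" and "open" are said of these compounds alone.

Measured so far in an assay for inhibition of protein disulfide-isomerase (Homo sapiens), with a stated time of 1 h; on this read-out higher numbers stand for weaker inhibition and lower numbers for stronger inhibition:
compound 1 `Oc1c(C(Nc2ccccn2)c2c(Cl)cccc2Cl)ccc2cccnc12`: 1890 nM
compound 2 `COc1ccc(C(Nc2cc(C)ccn2)c2ccc3cccnc3c2O)cc1O`: 150 nM
compound 3 `Cc1ccnc(NC(c2cc(C)ccc2C)c2ccc3cccnc3c2O)c1`: > 40000 nM, a limit of the assay, not a number

Compound 3 thus stands at the limit (the limit of > 40000 nM in this assay, at which 1 of the 3 values shown sits); only a bound is known for it. Compound 4 `Cc1ccnc(NC(c2ccc3cccnc3c2O)c2c(Cl)cccc2Cl)c1` differs from compound 3 by 2,6-dichlorophenyl in place of 2,5-dimethylphenyl on a saturated chain carbon bound to an aromatic carbon and a nitrogen on an aromatic ring. Within the data shown here, the one measured step at the same place is an at least 260-fold higher number from compound 2 to compound 3 (2.42 log units; beyond the scatter), which shows that the group on that carbon moves the read-out strongly. Compound 1 carries the same 2,6-dichlorophenyl at that carbon and gives 1890 nM in this assay, though its pyridine lacks the methyl. A large step back below the limit is therefore expected: an at least 16-fold lower number from compound 3 to compound 4 (1.20 log units; beyond the scatter). Compound 4 is estimated at 2500 nM, within 700 nM to 10000 nM.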

Compound 4, half-maximal inhibitory concentration: > 40000 nM
Compound 4 ended at the assay's limit; the forecaster's own chance of this, stated with the estimate: 10%; at least 16-fold (1.20 log units) between middle value and limit.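

In this assay, methyl in place of hydrogen on an aromatic carbon makes a large difference when 2,6-dichlorophenyl occupies the saturated chain carbon, giving an at least 21-fold higher number from compound 1 to compound 4 (1.32 log units; beyond the scatter). With that methyl present, 2,6-dichlorophenyl does not recover the read-out obtained with 3-hydroxy-4-methoxyphenyl: an at least 260-fold higher number from compound 2 to compound 4 (2.42 log units; beyond the scatter). The step between compound 3 and compound 4 cannot be read, and 2,5-dimethylphenyl and 2,6-dichlorophenyl cannot be ranked, because each compound gives only a limit: the limit of > 40000 nM in this assay, at which 2 of the 4 values shown sit.

As far as these compounds go, it remains open whether the hydroxy or the methoxy of compound 2 carries its value. An aminophenyl or a carboxyphenyl at this carbon also remains untested among the compounds shown.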